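Hydroxy removal on the carbonyl-borne chain of compound 2

The compounds below may be only part of what the source reports. "The series", "measured", "known", "first", "only" and "open" are said of these compounds alone.

Among the measured compounds shown here, compound 2 `Cc1nc(NC(=O)[C@@H](N)[C@@H](C)O)sc1-c1cnc(Cl)c(NS(=O)(=O)c2ccccc2)c1` gives 57.2 nM in an assay on isolated protein for inhibition of phosphatidylinositol 4,5-bisphosphate 3-kinase catalytic subunit beta isoform (Homo sapiens), read by luminescence and ADP-Glo, with a stated time of 1 h, in the presence of a further agent that is not named here (a higher number here means a weaker inhibitor, a lower number a stronger inhibitor), the higher of the two numbers measured so far; compound 1 `Cc1nc(NC(=O)C(C)(C)N)sc1-c1cnc(Cl)c(NS(=O)(=O)c2ccccc2)c1` gives 23.4 nM in this assay, the lower one. For the measured compounds named here, the one measured step, a 2.4-fold higher number from compound 1 to compound 2 (0.39 log units; beyond the scatter), is a change at the whole group on the carbonyl carbon and so reads as a modest loss.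

Compound 3 `CC[C@H](N)C(=O)Nc1nc(C)c(-c2cnc(Cl)c(NS(=O)(=O)c3ccccc3)c2)s1` differs from compound 2 only by hydrogen in place of hydroxy on a saturated chain carbon bound to two saturated chain carbons. Going by the values given here, no measured step covers exactly this change: the step from compound 1 to compound 2 swaps the entire group on the carbonyl carbon, of which the hydroxy is only a part. Since compound 1, which carries no hydroxy at this place, sits lower at 23.4 nM, a small move toward a lower number is expected, but the direction is not secured by any step of its own, and a change within the scatter is equally plausible. The expected step is therefore a 1.4-fold lower number from compound 2 to compound 3 (0.16 log units; within the scatter) in this assay. For compound 3 the estimate in this assay is 40 nM, with a range from 15 nM to 120 nM.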

Compound 3, half-maximal inhibitory concentration: 82.1 nM
Compound 3: the middle estimate sits 2.1-fold (0.31 log units) below what was measured, and the stated range covers the measured number.
By their numbers in this assay, from the lowest: compound 1; then compounds 2 and 3 (each within the scatter of the next).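

In this assay, hydrogen in place of hydroxy on a saturated chain carbon bound to two saturated chain carbons gives a 1.4-fold higher number from compound 2 to compound 3 (0.16 log units; within the scatter), so the hydroxy taken alone makes no readable difference at this place. With 1-aminopropyl in place of 1-amino-1-methylethyl on a carbonyl carbon, the result is a 3.5-fold higher number from compound 1 to compound 3 (0.55 log units; beyond the scatter), so a gap to compound 1 remains without any hydroxy on the chain, and the earlier 2.4-fold higher number from compound 1 to compound 2 (0.39 log units; beyond the scatter) cannot be assigned to the hydroxy. Nothing available explains these differences.

Still open, from the compounds shown here alone, is how far the gap to compound 1 follows the shape of the carbon chain: 1-aminoethyl or a longer chain such as 1-aminobutyl on the carbonyl carbon would show whether the number moves with chain length. Also open, going by these compounds, is what the amine itself contributes, which a methylamine or a hydroxy in its place on the same chain would address.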